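Cytotoxicity of a Sulfonate Ester and a Benzyl Ether

The source may report more compounds than this note shows. Statements on the series, on what has been measured and on what is new or still open speak of the compounds shown alone.

Measured compounds: compound 1 `Cc1ccc(S(=O)(=O)O[C@@H]2CO[C@H]3[C@@H]2OCc2nc4cc(Br)c(C)c(Br)c4n23)cc1` gives 88600 nM; compound 2 `Cc1c(Br)cc2nc3n(c2c1Br)[C@H]1OC[C@@H](OS(C)(=O)=O)[C@H]1OC3` gives 23700 nM.

In an ADME assay on HEp-2 cells (Homo sapiens) for cytotoxicity, read by MTT assay, with a stated time of 60 h (on this read-out higher numbers stand for lower toxicity in this test and lower numbers for higher toxicity in this test), compound 2 stands lowest of the two numbers shown, and its nearest neighbour, compound 1, lies higher by the step of a 3.7-fold lower number from compound 1 to compound 2 (0.57 log units; beyond the scatter). Compound 3 `Cc1c(Br)cc2nc3n(c2c1Br)[C@H]1OC[C@@H](OCc2ccccc2)[C@H]1OC3` is not yet measured. It differs from compound 2 by benzyl in place of methylsulfonyl on an oxygen on a saturated carbon. For the measured compounds named here, no measured step exchanges a methylsulfonyl for a benzyl; the only step available, a 3.7-fold lower number from compound 1 to compound 2 (0.57 log units; beyond the scatter), exchanged a 4-methylphenyl for a methyl on the sulfonyl sulfur and moved the number modestly downward. Compound 3 reintroduces a six-membered aromatic ring in the same region but removes the sulfonyl group altogether, so the step from compound 2 is expected to be modest and uncertain in direction, given as a 1.7-fold higher number from compound 2 to compound 3 (0.23 log units; within the scatter). Compound 3 is therefore estimated at 40000 nM, within the range 12000 nM to 130000 nM.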

Compound 3, half-maximal cytotoxic concentration: 115000 nM
Compound 3: middle estimate off by 2.9-fold (0.46 log units), on the low side, within the range that was stated.
By their numbers in this assay, from the lowest: compound 2; then compounds 1 and 3 (each within the scatter of the next).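

In this assay, exchanging methylsulfonyl for benzyl on this oxygen gives a clear rise (a 4.9-fold higher number from compound 2 to compound 3 (0.69 log units; beyond the scatter)), so the low number of compound 2 does not carry over to this ether. The other new step (a 1.3-fold higher number from compound 1 to compound 3 (0.11 log units; within the scatter)) shows that the (4-methylphenyl)sulfonyl and benzyl groups cannot be told apart here, although only the first contains a sulfonyl group. Among these three compounds, the two with a six-membered aromatic ring at this position read alike and the methylsulfonyl compound stands apart, but no evidence bearing on the reason is at hand.

The compounds shown leave open whether the lower number belongs to the methylsulfonyl group itself or simply goes with having no aromatic ring at this position. A free hydroxyl, a methyl ether or an amine on the same carbon would separate these two readings.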